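Ring to Chain: Expecting Topoisomerase Inhibition for Compound 3

The compounds below may be only part of what the source reports. "The series", "measured", "known", "first", "only" and "open" are said of these compounds alone.

Measured compounds:
- compound 1 `NCCNc1cc2c(cc1F)c(=O)c(C(=O)O)cn2Cc1ccc(-c2ccccc2)cc1` gives 72800 nM in an assay on isolated protein for inhibition of DNA topoisomerase 1 (Homo sapiens), with a stated time of 15 min; a higher number here means a weaker inhibitor, a lower number a stronger inhibitor
- compound 2 `NC[C@@H]1CCN(c2cc3c(cc2F)c(=O)c(C(=O)O)cn3Cc2ccc(-c3ccccc3)cc2)C1` gives 15600 nM in this assay

Among the measured compounds shown here, compound 2 stands at the lowest of the two numbers, and its only neighbour is compound 1, separated by a 4.7-fold lower number from compound 1 to compound 2 (0.67 log units; beyond the scatter). That single step is the one that bears on the next change. Compound 3 `CNCCCCNc1cc2c(cc1F)c(=O)c(C(=O)O)cn2Cc1ccc(-c2ccccc2)cc1` carries (4-(methylamino)butyl)amino in place of 3-(aminomethyl)pyrrolidin-1-yl on an aromatic carbon. The measured step went from a chain amine to the ring amine and gave a modest gain; compound 3 goes back from the ring to a chain, now a longer one ending in a methylamino group. Because the ring brought a 4.7-fold lower number from compound 1 to compound 2 (0.67 log units; beyond the scatter), undoing it is expected to cost a step of comparable size in the opposite direction, roughly a 3.2-fold higher number from compound 2 to compound 3 (0.51 log units; beyond the scatter). Compound 3 is therefore estimated at about 50000 nM, with a likely range of 15000 nM to 160000 nM, the longer chain leaving the outcome uncertain.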

Compound 3, half-maximal inhibitory concentration: 88300 nM
Estimate against measurement, compound 3: 1.8-fold (0.25 log units) below, within the range that was stated.
By their numbers in this assay, from the lowest: compound 2; then compounds 1 and 3 (each within the scatter of the next).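

In this assay, the two compounds with open chains stay together, with a 1.2-fold higher number from compound 1 to compound 3 (0.08 log units; within the scatter), so replacing (2-aminoethyl)amino with the longer (4-(methylamino)butyl)amino does not separate them. Compound 2 remains apart, with a 5.7-fold higher number from compound 2 to compound 3 (0.75 log units; beyond the scatter), although the group leaving and the group entering have the same count of heavy atoms; of the groups shown on this aromatic carbon, only the one with a five-membered non-aromatic ring gives the lower number. No measurement on hand accounts for this difference.

The compounds shown leave open whether a different cyclic amine, such as piperazin-1-yl, would stand with compound 2 or with the chain compounds. They also leave open how the opposite configuration at the stereocentre of 3-(aminomethyl)pyrrolidin-1-yl would compare with compound 2.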